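The compounds below may be only part of what the source reports. "The series", "measured", "known", "first", "only" and "open" are said of these compounds alone.

compound 1, `COc1ccc(Cn2nc(-c3ccccc3)c3cc(C(=N)Nc4ccccc4)nc(NC4CCCCC4)c32)cc1`: 1100 nM
compound 2, `COc1ccc(Cn2ncc3cc(C(=N)Nc4ccc(N5CCN(C)CC5)cc4)ncc32)cc1`: 6100 nM
compound 3, `COc1ccc(Cn2nc(-c3ccccc3)c3cc(C(=N)Nc4ccc(N5CCN(C)CC5)cc4)nc(NC4CCCCC4)c32)cc1`: 3540 nM

All three were read in a functional assay on PC-3 cells (Homo sapiens) for cytotoxicity, read by MTT assay, with a stated time of 72 h; a higher number here means a weaker inhibitor, a lower number a stronger inhibitor. Compound 3 and compound 1 share one core and differ in a single place, (hydrogen in place of 4-methylpiperazin-1-yl on an aromatic carbon); this gave a 3.2-fold lower number from compound 3 to compound 1 (0.51 log units; beyond the scatter). Compound 2 has a different core; how the core of compound 2 differs from that of compound 3 is not broken down here. Compound 2 shows the highest of the three numbers, but its gap to compound 3 lies within the scatter, so no order between those two is claimed.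

Compound 4, `COc1ccc(Cn2ncc3cc(C(=N)Nc4ccccc4)ncc32)cc1`, is compound 2 with the same change, (hydrogen in place of 4-methylpiperazin-1-yl on an aromatic carbon). This change occurs twice among these compounds, and the surroundings of the place are the same in both pairs. The step is expected to be similar because of a 3.2-fold lower number from compound 3 to compound 1 (0.51 log units; beyond the scatter), although it rests on one pair on another core. A step of a 3.1-fold lower number from compound 2 to compound 4 (0.48 log units; beyond the scatter) is expected. Compound 4 is estimated at 2000 nM, between 800 nM and 5000 nM.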

Compound 4, half-maximal inhibitory concentration: 36000 nM
Estimate against measurement, compound 4: 18-fold (1.26 log units) below; the whole stated range lies below it.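

In this assay, hydrogen in place of 4-methylpiperazin-1-yl gives a 5.9-fold higher number from compound 2 to compound 4 (0.77 log units; beyond the scatter). The change does not carry over from one core to the other, and its direction reverses: the same change on two cores in this assay, a 3.2-fold lower number (0.51 log units; beyond the scatter) from compound 3 to compound 1 and a 5.9-fold higher number (0.77 log units; beyond the scatter) from compound 2 to compound 4, 19-fold (1.28 log units) apart, beyond the scatter of two such steps

For the compounds shown here, the effect of this change therefore depends on the core in these two pairs, but each core carries only one pair, and the data do not show which difference between the cores is responsible.

From the compounds shown here alone, it remains open which of the differences between the two cores goes with the reversal. Going by these compounds, it is also open whether another group in the same place, such as morpholine or a dimethylamino group, would follow 4-methylpiperazin-1-yl on each core.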